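The source may hold more compounds than are shown below. What is called first, only, known or untested is meant among the compounds shown, and "the series" means these compounds.

In a functional assay on ECa-109 cells (Homo sapiens) for antiproliferative activity, read by MTT assay, with a stated time of 72 h (on this read-out lower numbers stand for stronger inhibition and higher numbers for weaker inhibition), four compounds sharing one core are compared through the group they carry on a nitrogen on an aromatic ring. Compound 1 `CCCSc1nc(N/N=C/c2cccs2)c2nnn(Cc3ccccc3)c2n1` gives > 64000 nM, and this is a limit of the assay, not a number. Compound 2 `CCCSc1nc(N/N=C/c2c[nH]c3ccccc23)c2nnn(Cc3ccccc3)c2n1` gives 8690 nM. Compound 3 `CCCSc1nc(N/N=C(\C)c2ccccc2)c2nnn(Cc3ccccc3)c2n1` gives 32200 nM, the higher of the two actual numbers, and its gap to compound 2 lies beyond the scatter.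

Compound 4 `CCCSc1nc(N/N=C/c2ccccc2F)c2nnn(Cc3ccccc3)c2n1` has not yet been measured. It departs from compound 3 through one exchange: a group of 9 heavy atoms (7 carbon, 1 nitrogen, 1 fluorine; one six-membered aromatic ring of carbon only) in place of a group of 9 heavy atoms (8 carbon, 1 nitrogen; one six-membered aromatic ring of carbon only), on a nitrogen on an aromatic ring. Among the compounds with values here, two measured steps bear on this exchange, since both alter the group at the same place. The first is an at least 7.3-fold lower number from compound 1 to compound 2 (0.86 log units; beyond the scatter), which lies beyond the scatter. The second is an at least 1.9-fold lower number from compound 1 to compound 3 (0.29 log units; that floor lies within the scatter), whose floor lies within the scatter. Both start from the limit, neither starts from compound 3, and neither brings in fluorine, so they show that this place can respond but give no direction for the new exchange. No clear shift is therefore expected in this assay, and the expected change, a 1.5-fold lower number from compound 3 to compound 4 (0.17 log units; within the scatter), is not expected to go beyond the scatter. Compound 4 is estimated at 22000 nM, with an expected range from 7000 nM to 55000 nM.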

Compound 4, half-maximal inhibitory concentration: > 64000 nM
Compound 4: only a limit was reported; the forecaster's own chance of this, stated with the estimate: 15%; middle value at least 2.9-fold (0.46 log units) away from the limit.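

In this assay, 2-fluorophenyl is no match for 1H-indol-3-yl at this place, with an at least 7.3-fold higher number from compound 2 to compound 4 (0.86 log units; beyond the scatter), so the gain seen for the indole-bearing compound 2 does not carry over to this fluorinated benzene ring. Against the group of compound 3 the picture is less firm, with an at least 1.9-fold higher number from compound 3 to compound 4 (0.29 log units; that floor lies within the scatter), so the data do not establish a real difference between these two groups. Compound 4 is reported only as a limit, as is compound 1, so the step between them cannot be read, and thiophen-2-yl and 2-fluorophenyl cannot be ranked: the limit of > 64000 nM in this assay, at which 2 of the 4 values shown sit.

Compound 3 and compound 4 differ both in the fluorine and in the methyl on the carbon with a double bond to nitrogen, and the compounds shown do not separate these two changes. They also leave open whether an amine or a carboxylic acid on the benzene ring would bring the number closer to that of compound 2, which gives 8690 nM.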